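The source may report more compounds than this note shows. Statements on the series, on what has been measured and on what is new or still open speak of the compounds shown alone.

Measured compounds:
compound 1 `Brc1cccc(/N=N/N2CCCCC2)c1`: > 100000 nM
compound 2 `CN(C)CCCNc1ccc(/N=N/c2ccc([N+](=O)[O-])cc2)cc1`: > 100000 nM
compound 3 `Cc1ccc(/N=N/N(CCCN(C)C)c2ccccc2)cc1`: > 100000 nM

In an ADME assay on BHK-21 cells (Mesocricetus auratus) for cytotoxicity, read by MTT assay, with a stated time of 96 h (a lower number here means that less compound is tolerated, a higher number that more compound is tolerated), compound 1 gives only a limit, not a number. Compound 2 likewise stops at a limit. Compound 3 stops at a limit as well. For the measured compounds named here, all three values sit at the limit of > 100000 nM in this assay, at which 3 of the 3 values shown sit, so no measured step between them can be sized, and no pair differing in one place has been compared. Compound 4 `c1ccc(/N=N/N2CCCCC2)cc1` differs from compound 1 by hydrogen in place of bromo on an aromatic carbon. Because every measured value rests at the limit of > 100000 nM in this assay, at which 3 of the 3 values shown sit, the step from compound 1 to compound 4 is expected to be a step that the limit leaves unreadable from compound 1 to compound 4, nothing beyond the scatter in this assay. Compound 4 is therefore expected to give 200000 nM, with a range from 80000 nM to 1000000 nM.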

Compound 4, half-maximal cytotoxic concentration: > 100000 nM
Compound 4: only a limit was reported; the forecaster's own chance of this, stated with the estimate: 85%; the middle value lies beyond the limit too.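

For the compounds shown here, no step from compound 1 to compound 4 can be read, since both results are limits and not numbers: the limit of > 100000 nM in this assay, at which 4 of the 4 values shown sit. The compounds shown leave open whether swapping bromo for hydrogen changes tolerance at all, and at what concentration any of them becomes cytotoxic.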